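The compounds below may be only part of what the source reports. "The series", "measured", "known", "first", "only" and "open" are said of these compounds alone.

The shared core, a carbamate of a piperidine bearing a diphenyl carbinol, appears in three measured compounds. Compound 1 `CCOc1ccc(OC(=O)N2CCC(C(O)(c3ccccc3)c3ccccc3)CC2)cc1` gives 1580 nM in a functional assay for antagonist activity at Neuropeptide Y receptor type 2 (Homo sapiens); on this read-out lower numbers stand for stronger inhibition and higher numbers for weaker inhibition. Compound 2 `O=C(Oc1ccc(S(=O)(=O)N2CCCC2)cc1)N1CCC(C(O)(c2ccccc2)c2ccccc2)CC1` gives 49 nM in this assay, and compound 3 `CS(=O)(=O)c1ccc(OC(=O)N2CCC(C(O)(c3ccccc3)c3ccccc3)CC2)cc1` gives 141 nM in this assay. Compound 3 stands second of the three: the step of a 2.9-fold higher number from compound 2 to compound 3 (0.46 log units; beyond the scatter) is modest, whereas an 11-fold lower number from compound 1 to compound 3 (1.05 log units; beyond the scatter) and a 32-fold lower number from compound 1 to compound 2 (1.51 log units; beyond the scatter) are both large.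

Compound 4 `CS(=O)(=O)Nc1ccc(OC(=O)N2CCC(C(O)(c3ccccc3)c3ccccc3)CC2)cc1` differs from compound 3 by one change: methanesulfonamido in place of methylsulfonyl on an aromatic carbon. Within the data shown here, no measured pair shows this exact change. Among the measured compounds shown here, the steps that bear on it, an 11-fold lower number from compound 1 to compound 3 (1.05 log units; beyond the scatter) and a 32-fold lower number from compound 1 to compound 2 (1.51 log units; beyond the scatter), show that a sulfonyl-containing group on this aromatic carbon gives far lower numbers than ethoxy, and a 2.9-fold higher number from compound 2 to compound 3 (0.46 log units; beyond the scatter) shows that what sits on the sulfur shifts the number only modestly. Since compound 4 keeps a sulfur-bearing group there, one expects only a small change, a 1.4-fold higher number from compound 3 to compound 4 (0.15 log units; within the scatter), if any beyond the scatter. Compound 4 is therefore estimated at 200 nM, with a range from 60 nM to 700 nM.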

Compound 4, half-maximal inhibitory concentration: 394 nM
Estimate against measurement, compound 4: 2.0-fold (0.29 log units) below; low and high end bracket the measured number.
By their numbers in this assay, from the lowest: compound 2; then compound 3; then compound 4; then compound 1.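

In this assay, methanesulfonamido in place of methylsulfonyl on this aromatic carbon is not a neutral exchange: the result is a 2.8-fold higher number from compound 3 to compound 4 (0.45 log units; beyond the scatter), so carrying a sulfonyl-containing group here does not by itself set the number. The advantage over ethoxy shrinks but remains, at a 4.0-fold lower number from compound 1 to compound 4 (0.60 log units; beyond the scatter), while the distance from (pyrrolidin-1-yl)sulfonyl widens to an 8.0-fold higher number from compound 2 to compound 4 (0.91 log units; beyond the scatter), so the sulfur-bearing groups at this position spread further apart than the first three compounds showed. Nothing in the data given here accounts for these differences.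

The compounds shown leave open whether the amide hydrogen of methanesulfonamido matters, which a methyl on that nitrogen would test. They also leave open how a longer chain on the sulfonyl sulfur, or a carboxylic acid on the same aromatic carbon, would read in this assay.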